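Oxygen-to-sulfur swap in a five-membered ring side group

The source may report more compounds than this note shows. Statements on the series, on what has been measured and on what is new or still open speak of the compounds shown alone.

Measured compounds:
- compound 1, `O=S(=O)(CC1=NCCO1)c1c(-c2ccc(Cl)cc2)nn(-c2ccccc2)c1-c1ccc(Cl)cc1`: "not active" (no number reported)
- compound 2, `COc1ccc(C2=NN(c3ccccc3)C(c3ccc(C)cc3)C2S(=O)(=O)CC2=NCCO2)cc1`: 67.7%
- compound 3, `O=S(=O)(CC1=NCCO1)c1n[nH]cc1-c1ccc(Cl)cc1`: "not active" (no number reported)

Three compounds have been run in a functional assay, tested at 100 ug/mL; on this read-out lower numbers stand for a weaker effect and higher numbers for a stronger effect at the one concentration tested. Compound 1 is reported as "not active" (no number reported) and compound 3 as "not active" (no number reported), neither with a number. Compound 2 is the only one with a figure: in this assay compound 2 gives 67.7%. Among the compounds with values here, because no two of the measured compounds differ in just one place, no step between them can be stated; compound 2 simply stands as the single numbered result.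

The next compound, compound 4, `COc1ccc(C2=NN(c3ccccc3)C(c3ccc(C)cc3)C2S(=O)(=O)CC2=NCCS2)cc1`, has not yet been measured. It differs from compound 2 in one spot: a group of 5 heavy atoms (3 carbon, 1 nitrogen, 1 sulfur; one five-membered non-aromatic ring with 2 hetero atoms) in place of a group of 5 heavy atoms (3 carbon, 1 nitrogen, 1 oxygen; one five-membered non-aromatic ring with 2 hetero atoms), on a saturated chain carbon bound to a sulfonyl sulfur. Within the data shown here, nothing among the measured compounds shows what this exchange does, so there is no measured step on which to rest a prediction. A step from compound 2 to compound 4 within the usual scatter, in no particular direction, is what is expected: a number 2.7 percentage points lower from compound 2 to compound 4 (within the scatter). For compound 4 in this assay the estimate is 65%, with a range from 45% to 85%.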

Compound 4, a percentage reported as activity, at one concentration (the size of the read-out at that concentration, not a potency): 47.9%
Beside the measured number, compound 4's estimate is 17.1 percentage points above it; measured number inside the range.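

In this assay, putting the sulfur-containing ring in place of the oxygen-containing one, on a saturated chain carbon bound to a sulfonyl sulfur, gives a number 19.8 percentage points lower from compound 2 to compound 4 (beyond the scatter). Within the data shown here, this is the first comparison here that changes only one place, and it shows that the read-out responds to this side ring: two five-membered rings with the same counts of hydrogen-bond donors and acceptors still give clearly different results at the one concentration tested. Nothing available here explains the drop.

As far as these compounds go, this finding rests on a single pair, so it remains open whether the same exchange would lower the number on the core of compound 1 or compound 3, neither of which has a number in this assay. Also open, from the compounds shown here alone, is how an amine or a carboxylic acid would perform at this place on the core of compound 2.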